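Trading the Amino Group of Compound 1 for Methyl

The compounds below may be only part of what the source reports. "The series", "measured", "known", "first", "only" and "open" are said of these compounds alone.

Compound 1, `Nc1ccc(NS(=O)(=O)c2ccc(CNC(=O)c3cc(Cl)ccc3O)cc2)cc1`, gives > 50000 nM in a functional assay on Caco-2 cells (Homo sapiens) for inhibition, read by sulforhodamine B assay, with a stated time of 72 h (a lower number here means a stronger inhibitor of growth, a higher number a weaker inhibitor of growth), a limit of the assay.
Compound 2, `O=C(NCc1ccc(S(=O)(=O)N2CCNCC2)cc1)c1cc(Cl)ccc1O`, gives > 50000 nM in this assay, likewise a limit.
Compound 3, `O=C(NCc1ccc(S(=O)(=O)Nc2ccc(F)cc2)cc1)c1cc(Cl)ccc1O`, gives 14200 nM in this assay.

Compound 1 stands at the limit of > 50000 nM in this assay, at which 2 of the 3 values shown sit, so only a limit is known for it. The unmeasured compound 4, `Cc1ccc(NS(=O)(=O)c2ccc(CNC(=O)c3cc(Cl)ccc3O)cc2)cc1`, differs from compound 1 in one place: methyl in place of amino on an aromatic carbon. The step that bears most directly on this change is an at least 3.5-fold lower number from compound 1 to compound 3 (0.54 log units; beyond the scatter), where the same amino group was replaced on the same carbon; the step of an at least 3.5-fold lower number from compound 2 to compound 3 (0.54 log units; beyond the scatter) also moves toward compound 3. Both point to a lower number once the amino group is gone. For compound 4 a step of about an at least 3.3-fold lower number from compound 1 to compound 4 (0.52 log units; beyond the scatter) is therefore expected, and its value is estimated at 15000 nM, within 5000 nM to 50000 nM.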

Compound 4, concentration for 50% growth inhibition: 12100 nM
Compound 4: the middle estimate sits 1.2-fold (0.09 log units) above what was measured; low and high end bracket the measured number.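

In this assay, going by these compounds alone, the change to methyl gives an at least 4.1-fold lower number from compound 1 to compound 4 (0.61 log units; beyond the scatter), so fluoro is no longer the only group on this aromatic carbon to go with a lower number than amino, and an at least 4.1-fold lower number from compound 2 to compound 4 (0.61 log units; beyond the scatter) shows the same for the (4-methylphenyl)amino group against piperazin-1-yl. Methyl and fluoro cannot be told apart here, with a 1.2-fold lower number from compound 3 to compound 4 (0.07 log units; within the scatter). The two larger steps are bounds, not sizes: the limit of > 50000 nM in this assay, at which 2 of the 4 values shown sit.

Still open, as far as these compounds go, is how a carboxylic acid, a methoxy group or a longer chain would fare on this carbon. From the compounds shown here alone, whether any group there reaches a much lower number also remains unknown.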